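Trimming a Side Chain: From Sec-Butyl to Isopropyl

The source may hold more compounds than are shown below. What is called first, only, known or untested is meant among the compounds shown, and "the series" means these compounds.

Compound 1 `CC[C@H](C)[C@H](NC(=O)CN(c1ncnc2c1ncn2C1CCCCO1)C1CC1)C(=O)OCc1ccccc1` is the weaker of the two compounds measured in a functional assay on the whole organism (Tail, strain ICR) with Mus musculus as the target, in the tail flick test, with a stated time of 30 min, at a dose of 25 umol/kg by the oral route; on this read-out higher numbers stand for a stronger effect at the one dose given and lower numbers for a weaker effect: compound 1 gives 25.6%, while compound 2 `O=C(CN(c1nc(Cl)nc2[nH]cnc12)C1CC1)N[C@@H](CCC(=O)OCc1ccccc1)C(=O)OCc1ccccc1` gives 52.8%, a gap beyond the usual scatter. Compound 3 `CC(C)[C@H](NC(=O)CN(c1ncnc2c1ncn2C1CCCCO1)C1CC1)C(=O)OCc1ccccc1` has not been measured. It differs from compound 1 in one place: hydrogen in place of methyl on a saturated chain carbon, three bonds along the chain from an amide-type nitrogen and a carbonyl carbon. Within the data shown here, removing one carbon from a chain this far from the amide is a small change, and with no comparable step among the measured compounds the expected step in this assay from a number 2.4 percentage points higher from compound 1 to compound 3 (within the scatter) is none beyond the scatter. Compound 3 is therefore estimated at 28%, with a range from 10% to 48%.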

Compound 3, a percentage reported as activity, at one dose (the size of the read-out at that dose, not a potency): 21.8%
Estimate against measurement, compound 3: 6.2 percentage points above; the measured number falls inside the stated range.
By their numbers in this assay, from the lowest: compounds 3 and 1 (each within the scatter of the next); then compound 2.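

In this assay, going from sec-butyl to isopropyl gives a number 3.8 percentage points lower from compound 1 to compound 3 (within the scatter), so at this one dose the two side chains cannot be told apart. A single methyl on this saturated chain carbon, three bonds along the chain from an amide-type nitrogen and a carbonyl carbon, therefore makes no readable difference to the effect. Nothing measured on these compounds gives a cause for this result. Still open, from the compounds shown here alone, is whether a larger change at this carbon, such as a longer chain, an amine or a carboxylic acid, would move the number beyond the scatter.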